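Shortening the Chain on the Double-Bonded Nitrogen

The source may report more compounds than this note shows. Statements on the series, on what has been measured and on what is new or still open speak of the compounds shown alone.

Among the compounds with values here, compound 2 `CCCCC/N=C(\C)c1c(O)c2ccccc2oc1=O` gives 6700 nM in an assay on isolated protein for inhibition of myosin-2 (Bos taurus), read by spectrophotometry, with a stated time of 24 min (a lower number here means a stronger inhibitor, a higher number a weaker inhibitor), the lowest of the two numbers measured so far. Compound 1 `C/C(=N\CCO)c1c(O)c2ccccc2oc1=O` gives 92000 nM in this assay. Within the data shown here, the single measured step, a 14-fold lower number from compound 1 to compound 2 (1.14 log units; beyond the scatter), came with propyl in place of hydroxy on a saturated chain carbon, two bonds along the chain from a double-bonded nitrogen, so a longer chain on that side went with a lower number.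

Compound 3 `C/C(=N\C(C)C)c1c(O)c2ccccc2oc1=O` has not yet been measured. It differs from compound 2 by isopropyl in place of pentyl on a double-bonded nitrogen, the chain on that nitrogen becoming shorter. Only a 14-fold lower number from compound 1 to compound 2 (1.14 log units; beyond the scatter) bears on this, and it suggests that shortening the chain is expected to raise the number, though probably by less than that step, since no hydroxy returns. Compound 3 is therefore expected to give about 25000 nM in this assay, between 8000 nM and 80000 nM. That amounts to an expected step of a 3.7-fold higher number from compound 2 to compound 3 (0.57 log units; beyond the scatter).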

Compound 3, half-maximal inhibitory concentration: >= 100000 nM
Compound 3 ended at the assay's limit; the forecaster's own chance of this, stated with the estimate: 5%; middle value at least 4.0-fold (0.60 log units) away from the limit.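

The value of compound 3 in this assay is a limit of the assay and not a number: the limit of >= 100000 nM in this assay, at which 1 of the 3 values shown sits. Even so, the group on the double-bonded nitrogen matters with no hydroxy involved, as replacing pentyl with isopropyl gives an at least 14-fold higher number from compound 2 to compound 3 (1.17 log units; beyond the scatter). Replacing 2-hydroxyethyl with isopropyl shows only an at least 1.0-fold higher number from compound 1 to compound 3 (0.03 log units; that floor lies within the scatter), so these two groups cannot be put in order.

Pentyl and isopropyl differ in both chain length and branching, so these compounds cannot show which of the two matters, and a straight propyl chain on this nitrogen would be needed to separate them. On these data alone, how a longer chain such as hexyl, or a chain ending in an amine, would compare with pentyl also remains open.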